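A few compounds are considered here, and "the series" means these few. Any claim that something is new, unique, unknown or untested is made for them only; others in the source may bear on it.

Compound 3, `Cn1c(=O)c(=O)n(C2CCCC2)c2nc(N/N=C/c3ccc(S(C)(=O)=O)cc3)ncc21`, gives 26600 nM in a functional assay on PC-3 cells (Homo sapiens) for antiproliferative activity, read by MTT assay (a higher number here means a weaker inhibitor, a lower number a stronger inhibitor), the lowest of the two numbers in hand; the nearest is compound 1, `Cn1c(=O)c(=O)n(C2CCCC2)c2nc(N/N=C/c3ccccc3)ncc21`, which gives 48200 nM, and the pair differ by a 1.8-fold lower number from compound 1 to compound 3 (0.26 log units; within the scatter). Compound 2, `Cn1c(=O)c(=O)n(C2CCCC2)c2nc(N/N=C/c3ccc(O)cc3)ncc21`, reaches only the limit of > 100000 nM in this assay, at which 1 of the 3 values shown sits, and gives > 100000 nM. The step from compound 2 to compound 3 was an at least 3.7-fold lower number from compound 2 to compound 3 (0.57 log units; beyond the scatter). Compound 4, `Cn1c(=O)c(=O)n(C2CCCC2)c2nc(N/N=C/c3cccc(O)c3)ncc21`, is not yet measured; it differs from compound 3 by 3-hydroxyphenyl in place of 4-(methylsulfonyl)phenyl on a carbon with a double bond to nitrogen. That step again trades the methylsulfonyl for a hydroxy, so the reverse of the step from compound 2 to compound 3 is the closest guide, and a higher number is expected. Compound 4 is therefore estimated at 80000 nM, between 30000 nM and 200000 nM, a step of a 3.0-fold higher number from compound 3 to compound 4 (0.48 log units; beyond the scatter) in this assay.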

Compound 4, half-maximal inhibitory concentration: 36300 nM
Estimate against measurement, compound 4: 2.2-fold (0.34 log units) above, and the stated range covers the measured number.
By their numbers in this assay, from the lowest: compounds 3, 4 and 1 (each within the scatter of the next). At a limit, above all of these: compound 2.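

Where the hydroxy sits on the ring matters in this assay: the change from 4-hydroxyphenyl to 3-hydroxyphenyl gives an at least 2.7-fold lower number from compound 2 to compound 4 (0.44 log units; beyond the scatter). Compound 2 stands at a limit of the assay, not at a number. With the hydroxy as 3-hydroxyphenyl, neither a 1.3-fold lower number from compound 1 to compound 4 (0.12 log units; within the scatter) nor a 1.4-fold higher number from compound 3 to compound 4 (0.14 log units; within the scatter) goes beyond the scatter, so a hydroxy on this ring does not always leave a number as high as that limit.

From the compounds shown here alone, whether an amine or a carboxylic acid on this ring would give a number clearly lower than these remains open. So does whether the hydroxy's effect would hold on a changed core.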